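Thiophene in place of chlorophenyl on an alkyne

The source may report more compounds than this note shows. Statements on the series, on what has been measured and on what is new or still open speak of the compounds shown alone.

Compound 1 `O=C1c2ccc(C#Cc3ccccc3)nc2CCN1C1CCCCC1`: 40 nM
Compound 2 `Cc1cccc(C#Cc2ccc3c(n2)CCN(C2CCCCC2)C3=O)c1`: 36 nM
Compound 3 `O=C1c2ccc(C#Cc3cccc(Cl)c3)nc2CCN1C1CCCCC1`: 171 nM

These three compounds share one core and differ only in the ring at the end of the triple bond. In a functional assay on HEK293 cells for positive allosteric modulation of metabotropic glutamate receptor 5 (Homo sapiens), read by FLIPR and calcium flux (a higher number here means that more compound is needed for the effect, a lower number that less compound is needed), compound 3 gives the highest number of the three; the nearest is compound 1, and a 4.3-fold higher number from compound 1 to compound 3 (0.63 log units; beyond the scatter). The step of a 4.8-fold higher number from compound 2 to compound 3 (0.68 log units; beyond the scatter) is of similar size, while a 1.1-fold lower number from compound 1 to compound 2 (0.05 log units; within the scatter).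

Compound 4 `O=C1c2ccc(C#Cc3cccs3)nc2CCN1C1CCCCC1` differs from compound 3 in that (thiophen-2-yl in place of 3-chlorophenyl on a triple-bonded carbon). Among the compounds with values here, no measured step replaces a six-membered ring by a five-membered one, so the bearing of the known steps is indirect. What they do show is that the chloro on the ring of compound 3 goes with a higher number than the bare ring of compound 1 and the methyl ring of compound 2. Compound 4 carries no chloro, and its ring is small and unsubstituted, closer in that respect to compound 1. The expected step is therefore a 2.4-fold lower number from compound 3 to compound 4 (0.39 log units; beyond the scatter), a lower number for compound 4. The estimate for compound 4 in this assay is 70 nM, with a range from 25 nM to 250 nM.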

Compound 4, half-maximal effective concentration: 13 nM
The estimate for compound 4 lay 5.4-fold (0.73 log units) above the measured number; measured number outside the range, below it.
By their numbers in this assay, from the lowest: compound 4; then compounds 2 and 1 (each within the scatter of the next); then compound 3.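

In this assay the ring on the triple-bonded carbon need not be six-membered, and thiophen-2-yl gives the lowest number of the four compounds (a 13-fold lower number from compound 3 to compound 4 (1.12 log units; beyond the scatter)) and also (a 2.8-fold lower number from compound 2 to compound 4 (0.44 log units; beyond the scatter)) and (a 3.1-fold lower number from compound 1 to compound 4 (0.49 log units; beyond the scatter)). The largest of these steps starts from the chlorinated ring, yet the step from the bare phenyl ring of compound 1 is also beyond the scatter, so removing the chloro does not account for the whole change: replacing the ring itself matters at this position. Nothing available explains why thiophen-2-yl gives a lower number than these phenyl rings.

The compounds shown leave open whether another five-membered ring, such as furan-2-yl or thiazol-2-yl, would give a similar number. They also leave open how a methyl group, a chloro group or an amine on the thiophene ring would shift it.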